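Compound 3: quinazolin-5-yl in place of 1,3-benzothiazol-7-yl

The source may hold more compounds than are shown below. What is called first, only, known or untested is meant among the compounds shown, and "the series" means these compounds.

In an ADME assay on microsomes from liver (Rattus norvegicus) for metabolic stability, read by LC-MS, with a stated time of 15 min, tested at 1 uM (a higher number here means that more of the compound is left, a lower number that less of the compound is left), compound 1 `Cc1cc(F)cnc1N1CCN(C(=O)CCCc2cccc3ncccc23)[C@@H](C)C1` gives 0.2% and compound 2 `Cc1cc(F)cnc1N1CCN(C(=O)CCCc2cccc3ncsc23)[C@@H](C)C1` gives 5.3% so compound 2 stands within the scatter of compound 1 and both numbers are low. The next structure is compound 3 `Cc1cc(F)cnc1N1CCN(C(=O)CCCc2cccc3ncncc23)[C@@H](C)C1` with the change quinazolin-5-yl in place of 1,3-benzothiazol-7-yl on a saturated chain carbon, three bonds along the chain from a carbonyl carbon in which quinazolin-5-yl takes the place of 1,3-benzothiazol-7-yl on a saturated chain carbon, three bonds along the chain from a carbonyl carbon. Among the measured compounds shown here, one measured step bears on this change: a number 5.1 percentage points higher from compound 1 to compound 2 (within the scatter) on putting 1,3-benzothiazol-7-yl in place of quinolin-5-yl at the same place. That single step is small, and it gives no ground to expect a move beyond the scatter in this assay here. The expected step is a number 1.3 percentage points lower from compound 2 to compound 3 (within the scatter) with no firm direction. The estimate for compound 3 is 4% with 0.5% to 15% as its expected range.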

Compound 3, percent of the compound remaining: 0%
Compound 3: middle estimate off by 4 percentage points, on the high side; the whole stated range lies above it.
By their numbers in this assay, from the lowest: compounds 3, 1 and 2 (each within the scatter of the next).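

Quinazolin-5-yl now joins quinolin-5-yl and 1,3-benzothiazol-7-yl on a saturated chain carbon, three bonds along the chain from a carbonyl carbon, and in this assay the exchange gives a number 5.3 percentage points lower from compound 2 to compound 3 (within the scatter) and also a number 0.2 percentage points lower from compound 1 to compound 3 (within the scatter). With all three pairs within the scatter, these three groups cannot be told apart at this place in this assay, and the numbers of all three compounds remain low. Nothing at hand gives a cause for these low numbers.

Still open, as far as these compounds go, is whether any change at this place can move the number beyond the scatter, for example an amine or a carboxylic acid on the ring group, or a longer chain. Also open, from the compounds shown here alone, is whether a change elsewhere on the shared core would do more than these exchanges.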